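Chain-extended butyl amide of the benzofuran ketone series

The source may hold more compounds than are shown below. What is called first, only, known or untested is meant among the compounds shown, and "the series" means these compounds.

The shared core is the ketone of compound 1 `CCCCc1oc2ccccc2c1C(=O)c1ccc(OCC(N)=O)cc1`, whose side chain ends in a primary amide. Measured in a functional assay on U-937 cells (Homo sapiens) for antiproliferative activity, read by MTT assay, with a stated time of 24 h (a lower number here means a stronger inhibitor, a higher number a weaker inhibitor), compound 1 gives 42200 nM, the highest of the three numbers seen so far. Compound 2 `CCCCNC(=O)COc1ccc(C(=O)c2c(CCCC)oc3ccccc23)cc1` gives 22800 nM in this assay, a step of a 1.9-fold lower number from compound 1 to compound 2 (0.27 log units; within the scatter). Compound 3 `CCCCc1oc2ccccc2c1C(=O)c1ccc(OCC(=O)N[C@H](C)c2ccccc2)cc1` gives 19800 nM, a step of a 2.1-fold lower number from compound 1 to compound 3 (0.33 log units; beyond the scatter), while from compound 2 to compound 3 the step is a 1.2-fold lower number from compound 2 to compound 3 (0.06 log units; within the scatter).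

Compound 4 `CCCCNC(=O)CCCOc1ccc(C(=O)c2c(CCCC)oc3ccccc23)cc1` differs from compound 1 by 2-(butylcarbamoyl)ethyl in place of carbamoyl on a saturated chain carbon bound to an oxygen on an aromatic ring. Among the measured compounds shown here, the nearest measured step is the one from compound 1 to compound 2, where the butyl on the amide nitrogen lowered the number within the scatter; no measured pair tests the longer chain between the ring oxygen and the amide. The expectation for compound 4 is therefore a step of a 2.1-fold lower number from compound 1 to compound 4 (0.32 log units; beyond the scatter), a modest lowering at most. Compound 4 is estimated at 20000 nM, within 8000 nM to 50000 nM.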

Compound 4, half-maximal inhibitory concentration: 24600 nM
Compound 4: middle estimate off by 1.2-fold (0.09 log units), on the low side; low and high end bracket the measured number.
By their numbers in this assay, from the lowest: compounds 3, 2, 4 and 1 (each within the scatter of the next, the first and the last beyond it).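

In this assay, among the compounds shown here, the change from butylcarbamoyl to 2-(butylcarbamoyl)ethyl tests the length of the chain directly for the first time, and the result is (a 1.1-fold higher number from compound 2 to compound 4 (0.03 log units; within the scatter)), so the longer chain does not separate compound 4 from the butyl amide with the shorter chain. Compound 4 also stays within the scatter of the 1-phenylethyl amide (a 1.2-fold higher number from compound 3 to compound 4 (0.09 log units; within the scatter)) and of the primary amide (a 1.7-fold lower number from compound 1 to compound 4 (0.23 log units; within the scatter)), whereas the step from that primary amide to the 1-phenylethyl amide was printed as beyond it. No supporting measurement accounts for these steps.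

The compounds shown leave open whether a carboxylic acid or an amine in place of the amide, or a still longer chain, would move the number beyond the scatter. They also leave open how the 1-phenylethyl group would read on the longer chain of compound 4.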